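From Vinyl to Pyrrolidinylmethyl: What to Expect of Compound 4

The source may report more compounds than this note shows. Statements on the series, on what has been measured and on what is new or still open speak of the compounds shown alone.

Of the compounds shown here, three built on a shared core have been measured in an assay for inhibition of RAC-alpha serine/threonine-protein kinase (Homo sapiens), read by HTRF, with a stated time of 1 h; on this read-out higher numbers stand for weaker inhibition and lower numbers for stronger inhibition. Compound 1 `CNC(=O)C[C@@H]1C[C@@H](c2ccc(Cl)c(Cl)c2)[C@H](NC(=O)c2cc(-c3c(Cl)cnn3C)c(Cl)o2)CN1` gives 2.64 nM, and compound 2 `Cn1ncc(Cl)c1-c1cc(C(=O)N[C@@H]2CN[C@H](CC(=O)O)C[C@H]2c2ccc(Cl)c(Cl)c2)oc1Cl` gives 1.94 nM; the step of a 1.4-fold lower number from compound 1 to compound 2 (0.13 log units; within the scatter) lies within the scatter. Compound 3 `C=CC[C@@H]1C[C@@H](c2ccc(Cl)c(Cl)c2)[C@H](NC(=O)c2cc(-c3c(Cl)cnn3C)c(Cl)o2)CN1`, which carries a vinyl group on a saturated chain carbon bound to a saturated ring carbon, gives 12.4 nM and stands with the highest number of the three, since a 4.7-fold higher number from compound 1 to compound 3 (0.67 log units; beyond the scatter) and a 6.4-fold higher number from compound 2 to compound 3 (0.81 log units; beyond the scatter) are both beyond the scatter.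

Compound 4 `Cn1ncc(Cl)c1-c1cc(C(=O)N[C@@H]2CN[C@H](CCN3CCCC3)C[C@H]2c2ccc(Cl)c(Cl)c2)oc1Cl` differs from compound 3 by (pyrrolidin-1-yl)methyl in place of vinyl on a saturated chain carbon bound to a saturated ring carbon. The two steps that bear on this change are the ones leading into compound 3 from compound 1 and from compound 2: each replaced methylcarbamoyl or carboxy with vinyl at this position and raised the number modestly. Among the measured compounds shown here, the incoming group restores a hydrogen-bond acceptor at the same position, though no measured pair tests a pyrrolidine-bearing chain, so the size of the recovery is uncertain. Compound 4 is therefore expected to move back down by a 3.1-fold lower number from compound 3 to compound 4 (0.49 log units; beyond the scatter) in this assay. The estimate for compound 4 is 4 nM, with a range from 1.5 nM to 12 nM.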

Compound 4, half-maximal inhibitory concentration: 6.41 nM
Beside the measured number, compound 4's estimate is 1.6-fold (0.20 log units) below it; low and high end bracket the measured number.
By their numbers in this assay, from the lowest: compounds 2 and 1 (each within the scatter of the next); then compounds 4 and 3 (each within the scatter of the next).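

In this assay, the (pyrrolidin-1-yl)methyl group on a saturated chain carbon bound to a saturated ring carbon gives a 1.9-fold lower number from compound 3 to compound 4 (0.29 log units; within the scatter), so adding this ring and its hydrogen-bond acceptor to the chain does not clearly separate the two compounds. The same group stays apart from both carbonyl-bearing chains, with a 3.3-fold higher number from compound 2 to compound 4 (0.52 log units; beyond the scatter) and a 2.4-fold higher number from compound 1 to compound 4 (0.39 log units; beyond the scatter), which shows that an amine-bearing chain at this position does not match the carboxy and methylcarbamoyl groups on this read-out. Nothing shown here gives a reason for these differences.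

The compounds shown leave open whether the ring itself matters, which a dimethylamino or morpholine group in place of the pyrrolidine would test. They also leave open how a longer chain ending in a carboxylic acid or a methylamide would compare with compound 1 and compound 2.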